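The source may report more compounds than this note shows. Statements on the series, on what has been measured and on what is new or still open speak of the compounds shown alone.

Measured so far:
- compound 3 `O=C(Nc1ncc(C(Oc2ccc3cc(Br)ccc3c2)c2ccc(Cl)cc2)s1)c1ccc(F)cc1Br`: > 50000 nM
- compound 1 `CCN(CC)C(=O)Nc1ncc(C(Oc2ccc3cc(Br)ccc3c2)c2ccc(Cl)cc2)s1`: "not toxic" (no number reported)
- compound 2 `O=C(Nc1ncc(C(Oc2ccc3cc(Br)ccc3c2)c2ccc(Cl)cc2)s1)C1CCCO1`: "not toxic" (no number reported)

All three share one core and differ only in the group attached to the nitrogen on the aromatic ring. They were tested in an ADME assay on HepG2 2.2.15 cells (Homo sapiens) for cytotoxicity; on this read-out higher numbers stand for lower toxicity in this test and lower numbers for higher toxicity in this test. For compound 3 the result is a limit, > 50000 nM, not a number; the cells tolerated the highest concentration tried. Compound 1 and compound 2 were each reported as not toxic without a number. So compound 3 stands exactly at the edge of what this assay can resolve, as shown by the limit of > 50000 nM in this assay, at which 1 of the 3 values shown sits, and nothing in the set points to any toxicity.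

The next compound, compound 4 `O=S(=O)(Nc1ncc(C(Oc2ccc3cc(Br)ccc3c2)c2ccc(Cl)cc2)s1)c1cccc2nsnc12`, keeps the same core and changes the group on that nitrogen:

a group of 12 heavy atoms (6 carbon, 2 nitrogen, 2 oxygen, 2 sulfur; one five-membered aromatic ring with 3 hetero atoms, one six-membered aromatic ring of carbon only) in place of a group of 10 heavy atoms (7 carbon, 1 oxygen, 1 fluorine, 1 bromine; one six-membered aromatic ring of carbon only), on a nitrogen on an aromatic ring

Going by the values given here, no step between two measured compounds is known here, so there is no measured size of change to lean on. With every result so far sitting at or beyond the limit, the expectation is for no change beyond the usual scatter in this assay, and a step that the limit leaves unreadable from compound 3 to compound 4 is what is estimated. Compound 4 is therefore expected to come out at about 60000 nM, with a range from 20000 nM to 200000 nM, most likely again as a limit.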

Compound 4, half-maximal cytotoxic concentration: "not toxic" (no number reported)
Nothing numeric was reported for compound 4, and the estimate cannot be compared.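

Going by these compounds alone, compound 4 was reported as not toxic, with no number, and compound 3 has only a limit, so no step between compound 3 and compound 4 can be read. The compounds shown leave open at what concentration, if any, each of them would begin to harm the cells in this assay.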